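Propargyloxy in place of allyloxy on the shared core

The source may hold more compounds than are shown below. What is called first, only, known or untested is meant among the compounds shown, and "the series" means these compounds.

Compound 1 `C=CCOc1ccc(C=O)cc1OC` is one of three compounds with results in a functional assay on CCRF-CEM cells (Homo sapiens) for cytotoxicity, with a stated time of 72 h; on this read-out lower numbers stand for stronger inhibition and higher numbers for weaker inhibition. In this assay compound 1 gives 14000 nM, the upper of the two numeric values available, though compound 2 `C#CCOc1ccc(/C=C/C(=O)c2ccc(OC)c(OC)c2)cc1OC` gives 8650 nM in the same assay and the gap between them lies within the usual scatter. Compound 3 `C#CCOc1ccc(/C=C/C(=O)c2ccc(C)cc2)cc1OC` returns only a limit rather than a number, > 50000 nM (the limit of > 50000 nM in this assay, at which 1 of the 3 values shown sits). Compound 4 `C#CCOc1ccc(C=O)cc1OC` has not yet been measured in this assay; it differs from compound 1 only in that (ethynyl in place of vinyl on a saturated chain carbon bound to an oxygen on an aromatic ring). For the measured compounds named here, no pair of measured compounds differs in one place, so the size of this step cannot be read from the data, and compound 2 and compound 3, which carry the propargyloxy group, differ from compound 1 elsewhere as well. The step from compound 1 to compound 4 is therefore expected to be small, a 1.1-fold higher number from compound 1 to compound 4 (0.03 log units; within the scatter), with no direction beyond the scatter. Compound 4 is estimated at 15000 nM, within a range from 5000 nM to 45000 nM.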

Compound 4, half-maximal inhibitory concentration: > 50000 nM
Compound 4 gave a limit, no number (the forecaster's own chance of this, stated with the estimate: 25%); middle value at least 3.3-fold (0.52 log units) from the limit.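

Replacing allyloxy with propargyloxy is not a neutral exchange at this position: in this assay the change gives an at least 3.5-fold higher number from compound 1 to compound 4 (0.55 log units; beyond the scatter). For the compounds shown here, the swap of vinyl for ethynyl on a saturated chain carbon bound to an oxygen on an aromatic ring keeps the heavy-atom count the same, yet by itself it moves the read-out towards weaker inhibition, which no earlier pair could show. The step has only a lower bound, since compound 4 gives a limit of the assay and not a number: the limit of > 50000 nM in this assay, at which 2 of the 4 values shown sit.

Whether the same change acts alike on the cores of compound 2 and compound 3 cannot be read, as the compounds shown hold no allyloxy partner for either. From the compounds shown here alone, how a longer chain or a terminal amine would read at this position also stays open.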